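Triazole amino linker variant of a cyanoguanidine antagonist

The compounds below may be only part of what the source reports. "The series", "measured", "known", "first", "only" and "open" are said of these compounds alone.

compound 1, `Cc1[nH]cnc1CCCCN/C(=N\C#N)NCCSc1ccccc1`, 5.36
compound 2, `N#C/N=C(\NCCCCc1nc(N)n[nH]1)NCCSc1ccccc1`, < 5

In a functional assay on Sf9 cells for antagonist activity at histamine H2 receptor (Homo sapiens), read by scintillation counting and GTPgammaS binding, with a stated time of 90 min (a lower number here means a less potent compound, a higher number a more potent compound, by a factor of ten per unit of this negative logarithm), compound 1 gives 5.36. For compound 2 this assay reports only a limit, < 5, so compound 2 stands at the bottom of the values shown, at the limit of < 5 in this assay, at which 1 of the 2 values shown sits. Among the compounds with values here, the step of a number at least 0.36 log units lower from compound 1 to compound 2 (beyond the scatter) is the only measured step. Compound 3, `N#C/N=C(\NCCCNc1nc(N)n[nH]1)NCCSc1ccccc1`, differs from compound 2 by (3-amino-1H-1,2,4-triazol-5-yl)amino in place of (3-amino-1H-1,2,4-triazol-5-yl)methyl on a saturated chain carbon, three bonds along the chain from an amine nitrogen. Within the data shown here, no measured step bears on this exchange of the methyl tether for an amino tether; the one step available concerns the ring itself and not its link to the chain, so it gives no direction for the change from compound 2 to compound 3. Because compound 2 sits at the limit of < 5 in this assay, at which 1 of the 2 values shown sits, the expected step that the limit leaves unreadable from compound 2 to compound 3 is taken as none beyond the scatter. Compound 3 is therefore estimated at 4.7, with a range from 4 to 5.3, and most likely again reported as a limit.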

Compound 3, negative logarithm of the antagonist equilibrium constant: < 5
Compound 3: only a limit was reported; the forecaster's own chance of this, stated with the estimate: 70%; the middle value does not contradict the limit.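

In this assay compound 3 is again reported only as a limit, < 5. Within the data shown here, the exchange of (5-methyl-1H-imidazol-4-yl)methyl for (3-amino-1H-1,2,4-triazol-5-yl)amino gives a number at least 0.36 log units lower from compound 1 to compound 3 (beyond the scatter), so the amino tether, like the methyl tether of compound 2, leaves the 3-amino-1H-1,2,4-triazol-5-yl ring short of the one measured value. The step between the two tethers themselves cannot be read, as both ends of it are limits: the limit of < 5 in this assay, at which 2 of the 3 values shown sit.

From the compounds shown here alone, whether the amino tether changes potency at all under that limit stays open, as does its effect on the 5-methyl-1H-imidazol-4-yl ring. Also open, going by these compounds, is whether a longer chain carrying the (3-amino-1H-1,2,4-triazol-5-yl)amino group would give a measurable value in this assay.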